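Methoxy on the styryl ring of compound 1

The source may report more compounds than this note shows. Statements on the series, on what has been measured and on what is new or still open speak of the compounds shown alone.

Compound 1 `Cc1nc(Nc2ccc(Cl)c(Cl)c2)sc1C(=O)/C=C/c1ccccc1` gives 22700 nM in a functional assay on NCI-H460 cells (Homo sapiens) for cytotoxicity, read by MTT assay; a lower number here means a stronger inhibitor, a higher number a weaker inhibitor. Compound 2 `Cc1cccc(Nc2nc(C)c(C(=O)/C=C/c3ccccc3)s2)c1` gives 21800 nM, so a 1.0-fold lower number from compound 1 to compound 2 (0.02 log units; within the scatter) and the two values sit within the scatter of each other. Compound 3 `Cc1ccc(Nc2nc(C)c(C(=O)/C=C/c3ccccc3)s2)cc1` reaches only > 25000 nM, which is a limit of this assay and not a number (the limit of > 25000 nM in this assay, at which 1 of the 3 values shown sits). The steps of an at least 1.1-fold higher number from compound 1 to compound 3 (0.04 log units; that floor lies within the scatter) and an at least 1.1-fold higher number from compound 2 to compound 3 (0.05 log units; that floor lies within the scatter) stop at that limit. Compound 4 `COc1cccc(/C=C/C(=O)c2sc(Nc3ccc(Cl)c(Cl)c3)nc2C)c1` carries methoxy in place of hydrogen on an aromatic carbon. Every measured step changes the group on the nitrogen of the shared core; none touches the ring where the methoxy enters, and none moved beyond the scatter. Among the compounds with values here, no measured step therefore bears on this change directly, and no movement beyond the scatter is expected in this assay. Compound 4 is estimated at 22000 nM, between 8000 nM and 45000 nM. The step of a 1.0-fold lower number from compound 1 to compound 4 (0.01 log units; within the scatter) is expected to remain within the scatter.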

Compound 4, half-maximal inhibitory concentration: 20100 nM
Estimate against measurement, compound 4: 1.1-fold (0.04 log units) above, within the range that was stated.
By their numbers in this assay, from the lowest: compounds 4, 2 and 1 (each within the scatter of the next). At a limit, above all of these: compound 3.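

Within the data shown here, the earlier steps all changed the group on the nitrogen, so this is the only reading on the styryl ring. In this assay, phenyl to 3-methoxyphenyl gives a 1.1-fold lower number from compound 1 to compound 4 (0.05 log units; within the scatter), so methoxy at this position produces no movement beyond the scatter. Nothing measured here bears on the cause of this result.

Going by these compounds, whether an amine or a carboxylic acid at this position would move the number beyond the scatter remains open. So does whether methoxy gives the same result with 3-methylphenyl on the nitrogen of the shared core.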